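This account rests on a few compounds, and the source may have more. Where it says the series, first, only, none or still open, it means among the compounds named here.

Compound 1 `COc1ccccc1-c1cc(CN(C)C)ccc1Cl`: 43%; compound 2 `CCNCc1ccc(Cl)c(-c2ccccc2OC)c1`: "not active" (no number reported); compound 3 `COc1ccccc1-c1cc(C2CCNC2)ccc1Cl`: 54%.

For the measured compounds named here, in a functional assay on HEK293 cells for agonist activity at 5-hydroxytryptamine receptor 7 (Homo sapiens), read by a luciferase reporter and beta-arrestin recruitment, with a stated time of 22 h (a lower number here means a smaller maximal response, a higher number a larger maximal response), compound 3 stands highest of the two compounds that report a number, and the only measured step at this position is a number 11 percentage points higher from compound 1 to compound 3 (beyond the scatter), a modest rise toward the ring group that now leaves. Compound 4 `CCCNCc1ccc(Cl)c(-c2ccccc2OC)c1` has not been measured; it differs from compound 3 in one place: (propylamino)methyl in place of pyrrolidin-3-yl on an aromatic carbon. A group with no ring at this place is also carried by compound 2, and in this assay compound 2 gives "not active" (no number reported). Both pieces of evidence point the same way, so a downward step beyond the scatter is expected, a number 24 percentage points lower from compound 3 to compound 4 (beyond the scatter). Compound 4 is estimated at 30%, with a range from 0% to 55%.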

Compound 4, largest response reached (Emax), in percent of the reference or control that the assay uses: "not active" (no number reported)
The entry for compound 4 holds no number; the estimate stays without a comparison.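

Compound 4 gives "not active" (no number reported), so no step from compound 3 to compound 4 can be read, and nothing shown here speaks to a reason. As far as these compounds go, how far compound 4 truly lies from compound 3 in maximal response stays open.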